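Ureas and amide at the enamine nitrogen of the bicyclic sulfonate

This account rests on a few compounds, and the source may have more. Where it says the series, first, only, none or still open, it means among the compounds named here.

Compound 1 `CCNC(=O)NC1=CS(=O)(=O)O[C@@]12[C@@H](CO[Si](C)(C)C(C)(C)C)O[C@@H](n1cc(C)c(=O)n(C)c1=O)[C@@H]2O[Si](C)(C)C(C)(C)C` and compound 2 `Cc1cn([C@@H]2O[C@H](CO[Si](C)(C)C(C)(C)C)[C@@]3(OS(=O)(=O)C=C3NC(=O)c3ccccc3)[C@H]2O[Si](C)(C)C(C)(C)C)c(=O)n(C)c1=O` carry an ethylcarbamoyl and a benzoyl group on the amine nitrogen of the shared core. In a functional assay on HEL cells (Homo sapiens) (on this read-out lower numbers stand for higher toxicity in this test and higher numbers for lower toxicity in this test), compound 1 gives 10000 nM and compound 2 gives 9700 nM; the step of a 1.0-fold lower number from compound 1 to compound 2 (0.01 log units; within the scatter) is within the scatter. Compound 3 `COC(=O)C(=O)CNC1=CS(=O)(=O)O[C@@]12[C@@H](CO[Si](C)(C)C(C)(C)C)O[C@@H](n1cc(C)c(=O)n(C)c1=O)[C@@H]2O[Si](C)(C)C(C)(C)C` instead carries a ((methoxycarbonyl)carbonyl)methyl group there. In this assay compound 3 reaches only the limit > 200000 nM, so no number is known for it. The steps of an at least 20-fold higher number from compound 1 to compound 3 (1.30 log units; beyond the scatter) and an at least 20-fold higher number from compound 2 to compound 3 (1.31 log units; beyond the scatter) are both large and point the same way. Compound 4 `Cc1cn([C@@H]2O[C@H](CO[Si](C)(C)C(C)(C)C)[C@@]3(OS(=O)(=O)C=C3NC(N)=O)[C@H]2O[Si](C)(C)C(C)(C)C)c(=O)n(C)c1=O` differs from compound 3 by carbamoyl in place of ((methoxycarbonyl)carbonyl)methyl on an amine nitrogen, so that compound 4 again carries a carbamoyl group like the ethylcarbamoyl of compound 1. The two measured steps bearing on this change both went to a higher number when the acyl or carbamoyl group was replaced; reversing that replacement is expected to give a large step to a lower number. Compound 4 is therefore expected to sit near 15000 nM (range 5000 nM to 60000 nM) in this assay, a step of an at least 13-fold lower number from compound 3 to compound 4 (1.12 log units; beyond the scatter).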

Compound 4, half-maximal cytotoxic concentration: 11000 nM
The estimate for compound 4 lay 1.4-fold (0.13 log units) above the measured number; low and high end bracket the measured number.
By their numbers in this assay, from the lowest: compounds 2, 1 and 4 (each within the scatter of the next). At a limit, above all of these: compound 3.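

In this assay, the carbamoyl group of compound 4 stays with the two other groups on the amine nitrogen: a 1.1-fold higher number from compound 2 to compound 4 (0.05 log units; within the scatter), and a 1.1-fold higher number from compound 1 to compound 4 (0.04 log units; within the scatter). Both steps lie within the scatter, so neither hydrogen against ethyl on the amide-type nitrogen nor amino against phenyl on the carbonyl carbon is told apart here. The large step of an at least 18-fold lower number from compound 3 to compound 4 (1.25 log units; beyond the scatter) shows that the separation of the ((methoxycarbonyl)carbonyl)methyl compound from the compounds with a carbonyl directly on this nitrogen holds for a third such group.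

On these data alone, the true size of that step stays open because compound 3 stands only at a limit: the limit of > 200000 nM in this assay, at which 1 of the 4 values shown sits. Also open is where a free amine on this nitrogen, or a carboxylic acid in place of the methyl ester of compound 3, would fall.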